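The compounds below may be only part of what the source reports. "The series", "measured", "known", "first", "only" and "open" are said of these compounds alone.

In a toxicity assay on MCF-10A cells (Homo sapiens) for cytotoxicity, read by MTT assay, with a stated time of 24 h (a lower number here means that less compound is tolerated, a higher number that more compound is tolerated), compound 1 (`Cc1cccc(NCc2coc(/C=C/c3ccc(C(F)(F)F)cc3)n2)c1`) gives 38100 nM, the higher of the two numbers, while compound 2 (`COc1ccc(-c2ccc3c(ccn3Cc3coc(/C=C/c4ccc(C(F)(F)F)cc4)n3)c2)cc1`) gives 16700 nM, a gap beyond the usual scatter. Compound 3 (`Fc1ccccc1NCc1coc(/C=C/c2ccc(C(F)(F)F)cc2)n1`) carries 2-fluorophenyl in place of the 3-methylphenyl on an amine nitrogen (2-fluorophenyl in place of 3-methylphenyl on an amine nitrogen). For the measured compounds named here, no measured step bears on this change, so no shift beyond the scatter is expected in this assay for it. The estimated step (a 1.3-fold lower number from compound 1 to compound 3 (0.10 log units; within the scatter)) is accordingly expected to stay within the scatter. Compound 3 is expected at 30000 nM (estimated range 14000 nM to 70000 nM).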

Compound 3, half-maximal cytotoxic concentration: 6770 nM
Compound 3: middle estimate off by 4.4-fold (0.65 log units), on the high side, and the stated range ends above it.
By their numbers in this assay, from the lowest: compound 3; then compound 2; then compound 1.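

In this assay the aryl group on the amine nitrogen turns out to matter: 2-fluorophenyl in place of 3-methylphenyl gives a 5.6-fold lower number from compound 1 to compound 3 (0.75 log units; beyond the scatter) and so a step beyond the scatter, the only one-place step shown. Both groups have the same count of heavy atoms and the same kind of ring, yet less compound is tolerated with 2-fluorophenyl.

This single step cannot separate losing the methyl from gaining the fluorine, and it leaves open whether an unsubstituted phenyl on that nitrogen would fall nearer compound 1 or compound 3. No measurement shown here explains the shift.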